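Methoxy for hydroxy on two benzothiophene-bearing cores

The source may report more compounds than this note shows. Statements on the series, on what has been measured and on what is new or still open speak of the compounds shown alone.

Working notes on the series. In a functional assay on A549 cells (Homo sapiens) for antiproliferative activity, read by sulforhodamine B assay, with a stated time of 72 h (on this read-out higher numbers stand for weaker inhibition and lower numbers for stronger inhibition), compound 1 `COc1cc2occ(-c3csc4ccccc34)c(=O)c2c(OC)c1OC` gives 640 nM. Compound 2 `COc1cc2occ(-c3csc4ccccc34)c(=O)c2c(OC)c1O` reaches only the limit of this assay, > 10000 nM. The change from compound 2 to compound 1, (methyl in place of hydrogen on an oxygen on an aromatic ring), gave an at least 15-fold lower number from compound 2 to compound 1 (1.19 log units; beyond the scatter); the size of that step is only a lower bound because of the limit of > 10000 nM in this assay, at which 1 of the 3 values shown sits.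

Compound 3 `COc1ccc(O)c(C(=O)/C=C/c2csc3ccccc23)c1` carries a different core; the difference between the core of compound 3 and the core of compound 2 is not broken down here. In this assay compound 3 gives 580 nM, which sits within the scatter of the number for compound 1.

Compound 4 `COc1ccc(OC)c(C(=O)/C=C/c2csc3ccccc23)c1` is not yet measured. It differs from compound 3 by methyl in place of hydrogen on an oxygen on an aromatic ring, the same change as that from compound 2 to compound 1, at a place described in the same words. Among the compounds with values here, on the strength of that one earlier step, compound 4 is expected to give a lower number than compound 3, though more cautiously, since the cores differ and only one example of the change is in hand: the expected step is a 2.9-fold lower number from compound 3 to compound 4 (0.46 log units; beyond the scatter). The estimate for compound 4 is 200 nM, with a range from 40 nM to 1500 nM.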

Compound 4, half-maximal inhibitory concentration: 4100 nM
Estimate against measurement, compound 4: 21-fold (1.31 log units) below; the measured number lies above the stated range.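

In this assay, the change from hydroxy to methoxy gave a 7.1-fold higher number from compound 3 to compound 4 (0.85 log units; beyond the scatter) on the core of compound 3, which runs opposite to the step seen on the core of compound 1, and the two steps differ: the same change on two cores in this assay, an at least 15-fold lower number (1.19 log units; beyond the scatter) from compound 2 to compound 1 and a 7.1-fold higher number (0.85 log units; beyond the scatter) from compound 3 to compound 4, at least 110-fold (2.04 log units) apart, beyond the scatter of two such steps. The earlier step is only a lower bound, and so is the gap between the two steps: the limit of > 10000 nM in this assay, at which 1 of the 4 values shown sits. This shows that the direction of the change cannot be assumed to carry from one core to the other in this series, but with a single example on each core it does not show why the direction reverses or what the change would do on any further core.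

The compounds shown leave open whether a larger group on that oxygen, such as ethyl or a longer chain, would follow the methyl result on either core. They also leave open how an amine in place of the hydroxy would read in this assay on each core.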